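Demethylating the phenol in a bis-aryl pyrazole urea series

A few compounds are considered here, and "the series" means these few. Any claim that something is new, unique, unknown or untested is made for them only; others in the source may bear on it.

In a functional assay on TK-10 cells (Homo sapiens) for inhibition, read by sulforhodamine B assay, with a stated time of 48 h (a lower number here means that less compound is tolerated, a higher number that more compound is tolerated), compound 1 `O=C(Nc1cccc(-n2cc(-c3ccncc3)c(-c3ccc(Cl)c(O)c3)n2)c1)Nc1cccc(C(F)(F)F)c1` is characterised only by a limit: it gives > 32500 nM. Compound 2 `COc1cc(-c2nn(-c3cccc(NC(=O)Nc4ccc(Cl)c(Cl)c4)c3)cc2-c2ccncc2)ccc1Cl`, which carries a methoxy group on the chlorophenyl ring and a dichlorophenyl urea, is likewise reported only as a limit in this assay, where compound 2 gives > 50000 nM. Within the data shown here, compound 2 therefore stands at the top of what this assay reports, and the same holds for compound 1; neither value is a number, and no step between them can be stated, as the two limits the limit of > 32500 nM in this assay, at which 1 of the 2 values shown sits, and the limit of > 50000 nM in this assay, at which 1 of the 2 values shown sits, both sit at the edge of the measured range.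

Compound 3 `O=C(Nc1cccc(-n2cc(-c3ccncc3)c(-c3ccc(Cl)c(O)c3)n2)c1)Nc1ccc(Cl)c(Cl)c1` keeps the dichlorophenyl urea of compound 2 and introduces the change (hydrogen in place of methyl on an oxygen on an aromatic ring), so that the aromatic ring now bears a hydroxy group instead of a methoxy group, as in compound 1. Since both measured compounds reach only limits in this assay, the step from compound 2 to compound 3 is expected to be a number no higher from compound 2 to compound 3 (the limit leaves the size open), that is, no change beyond the scatter. Compound 3 is accordingly expected to give about 50000 nM in this assay, in a range from 20000 nM to 100000 nM, most probably reported again as a limit.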

Compound 3, concentration lethal to 50% of the cells: > 32500 nM
Compound 3 was reported as a limit; the forecaster's own chance of this, stated with the estimate: 75%; the middle value lies beyond the limit too.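

In this assay compound 3 gives > 32500 nM, which is a limit and not a number. No step can be read from compound 1 or compound 2 to compound 3. The compounds shown leave open whether methoxy to hydroxy, or 3-(trifluoromethyl)phenyl to 3,4-dichlorophenyl, changes the lethal concentration at all.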